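The source may hold more compounds than are shown below. What is called first, only, known or untested is meant among the compounds shown, and "the series" means these compounds.

Compound 1 has the structure `Nc1cccc(Nc2c(C(=O)NCc3ccc(F)cc3)nc(Br)c3cccnc23)c1`. In a functional assay on MCF7 cells (Homo sapiens) for cytotoxicity, read by MTT assay, with a stated time of 72 h (a higher number here means a weaker inhibitor, a lower number a stronger inhibitor), compound 1 gives 8000 nM. Two companions share its core. Compound 3, `N[C@H]1CC[C@H](Nc2c(C(=O)NCc3ccc(F)cc3)nc(N3CCCCC3)c3cccnc23)CC1`, carries an amine on a saturated ring and a piperidine in place of the bromo group; in this assay compound 3 gives 5000 nM. The two numbers lie within the scatter of each other, so neither compound can be called the stronger. Compound 2, `N[C@H]1CC[C@H](Nc2c(C(=O)NCc3ccco3)nc(Br)c3cccnc23)CC1`, was also made; in this assay compound 2 gives "not determined" (no result reported), so no number is available for it.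

Compound 4, `O=C(NCc1ccc(F)cc1)c1nc(Br)c2cccnc2c1N1CCNCC1`, differs from compound 1 in one place: piperazin-1-yl in place of (3-aminophenyl)amino on an aromatic carbon. The carbon bearing the group keeps its neighbours otherwise unchanged. Going by the values given here, no measured pair shows this exact exchange, so the step can only be guessed from the spread of the known numbers. Because compound 1 gives 8000 nM and compound 3, with a different amine-bearing ring, gives 5000 nM, the step from compound 1 to compound 4 is expected to be small, a 1.3-fold higher number from compound 1 to compound 4 (0.10 log units; within the scatter), within the usual scatter. Compound 4 is therefore estimated at 10000 nM, in the range 3000 nM to 30000 nM.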

Compound 4, half-maximal inhibitory concentration: 7000 nM
Compound 4: middle estimate off by 1.4-fold (0.15 log units), on the high side; the measured number falls inside the stated range.
By their numbers in this assay, from the lowest: compounds 3, 4 and 1 (each within the scatter of the next).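

In this assay the exchange of (3-aminophenyl)amino for piperazin-1-yl gives a 1.1-fold lower number from compound 1 to compound 4 (0.06 log units; within the scatter), so this pair cannot be told apart at this position on the core. The change replaces a six-membered aromatic ring of carbon only with a non-aromatic ring with 2 hetero atoms, and it also takes the count from 2 hydrogen-bond donors to 1, yet the step stays within the scatter. Nothing measured here offers a reason for this result.

As far as these compounds go, it remains open whether a morpholine ring or an open-chain ethylamino group at this position would give a step beyond the scatter. From the compounds shown here alone, it is also open whether the same exchange would give a similar step with a piperidine in place of the bromo group.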